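From Methoxy to Hydroxy on a Shared Core

The compounds below may be only part of what the source reports. "The series", "measured", "known", "first", "only" and "open" are said of these compounds alone.

Compound 3 `COc1cc(-c2nn(-c3cccc(NC(=O)Nc4ccc(Cl)c(Cl)c4)c3)cc2-c2ccncc2)ccc1Cl` is the only one of the three measured compounds to give a number: in a functional assay on KM12 cells (Homo sapiens) for inhibition, read by sulforhodamine B assay, with a stated time of 48 h (on this read-out higher numbers stand for weaker inhibition of growth and lower numbers for stronger inhibition of growth), compound 3 gives 2770 nM. Compound 1 `O=C(Nc1cccc(-n2cc(-c3ccncc3)c(-c3ccc(Cl)c(O)c3)n2)c1)Nc1cccc(C(F)(F)F)c1` reaches only a limit, > 32500 nM, in this assay. Compound 2 `COc1cc(-c2nn(-c3cccc(NC(=O)c4cccc(C(F)(F)F)c4)c3)cc2-c2ccncc2)ccc1Cl` likewise stops at a limit, > 50000 nM, in this assay. Going by the values given here, the single step measured in one place runs an at least 18-fold lower number from compound 2 to compound 3 (1.25 log units; beyond the scatter), where a number emerges from the limit (the limit of > 50000 nM in this assay, at which 1 of the 3 values shown sits). Compound 4 `O=C(Nc1cccc(-n2cc(-c3ccncc3)c(-c3ccc(Cl)c(O)c3)n2)c1)Nc1ccc(Cl)c(Cl)c1` departs from compound 3 by hydrogen in place of methyl on an oxygen on an aromatic ring, that is, methoxy to hydroxy on the 4-chloro-3-methoxyphenyl group. Among the compounds with values here, no measured pair differs in that place alone; compound 1 also carries the hydroxy but with another urea end, so its limit of > 32500 nM in this assay, at which 1 of the 3 values shown sits, does not speak to this change on its own. The step from compound 2 to compound 3 concerns the other end of the molecule and gives no guidance here. A step of a 1.3-fold higher number from compound 3 to compound 4 (0.10 log units; within the scatter) is therefore expected, lying within the scatter in either direction. Compound 4 is estimated at 3500 nM, with a range from 900 nM to 14000 nM.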

Compound 4, concentration for total growth inhibition: 4470 nM
The estimate for compound 4 lay 1.3-fold (0.11 log units) below the measured number; the measured number falls inside the stated range.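

In this assay, methoxy to hydroxy on the 4-chloro-3-methoxyphenyl group can now be read on its own, and it gives a 1.6-fold higher number from compound 3 to compound 4 (0.21 log units; within the scatter), so this position takes either group with the 3,4-dichlorophenyl urea end in place. Going by these compounds alone, with the hydroxy held constant, the urea end can also be read alone for the first time: 3,4-dichlorophenyl in place of 3-(trifluoromethyl)phenyl gives an at least 7.2-fold lower number from compound 1 to compound 4 (0.86 log units; beyond the scatter). That step starts from a limit and not a number, which belongs to compound 1: the limit of > 32500 nM in this assay, at which 1 of the 4 values shown sits.

The compounds shown leave open what an ethoxy group, a longer chain or an amine at this position would give. Within the data shown here, they also leave open whether methoxy to hydroxy reads the same with any other urea end, since only this one pair isolates the change.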